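A dimethylamino group added to the phenyl of compound 2

The source may report more compounds than this note shows. Statements on the series, on what has been measured and on what is new or still open speak of the compounds shown alone.

In a functional assay on HCT-116 cells (Homo sapiens) for antiproliferative activity, read by resazurin assay, with a stated time of 5 days (a higher number here means a weaker inhibitor, a lower number a stronger inhibitor), compound 1 (`COCc1ccc(C(=O)NCc2ccc3cc(C(=O)NO)sc3c2F)o1`) gives 310 nM and compound 2 (`O=C(NCc1ccc2cc(C(=O)NO)sc2c1F)c1ccccc1`) gives 980 nM as the higher of the two numbers, which marks the weaker inhibitor of the pair. Compound 3 (`CN(C)c1ccc(C(=O)NCc2ccc3cc(C(=O)NO)sc3c2F)cc1`) keeps all of compound 2 except for one change: dimethylamino in place of hydrogen on an aromatic carbon, para to a large group (dimethylamino in place of hydrogen on an aromatic carbon). Within the data shown here, the only measured step, a 3.2-fold higher number from compound 1 to compound 2 (0.50 log units; beyond the scatter) with phenyl in place of 5-(methoxymethyl)furan-2-yl on a carbonyl carbon, is modest but beyond the scatter. That step swaps a whole ring, so it is only a loose guide to a group added to the phenyl. The expectation is a small move toward a lower number, estimated as a 1.6-fold lower number from compound 2 to compound 3 (0.21 log units; within the scatter) and not clearly beyond the scatter. Compound 3 is estimated at 600 nM with an expected range from 200 nM to 1800 nM in this assay for now.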

Compound 3, half-maximal inhibitory concentration: 60 nM
Beside the measured number, compound 3's estimate is 10-fold (1.00 log units) above it, outside the stated range (below it).
By their numbers in this assay, from the lowest: compound 3; then compound 1; then compound 2.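

In this assay, the phenyl ring proves to be a sensitive place in this series: dimethylamino in place of hydrogen on an aromatic carbon, para to a large group, gives a 16-fold lower number from compound 2 to compound 3 (1.21 log units; beyond the scatter). Among these compounds, the earlier step showed only that exchanging one whole ring for another could shift the number, whereas this one shows a large shift from a single group added to the phenyl, and the 4-(dimethylamino)phenyl group also outdoes the 5-(methoxymethyl)furan-2-yl group, with a 5.2-fold lower number from compound 1 to compound 3 (0.71 log units; beyond the scatter). Nothing available here accounts for the size of this step.

The compounds shown leave open whether dimethylamino is special here or whether a plain amino group, a methoxy group or a pyrrolidine ring would serve as well. Also open, from the compounds shown here alone, is how the same group would fare on another carbon of the phenyl ring.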